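The source may hold more compounds than are shown below. What is called first, only, known or untested is meant among the compounds shown, and "the series" means these compounds.

Measured compounds in the series:

compound 1 `COC(=O)C1=C(C)N=C(C)/C(=C(/O)OC)C1c1cccc(N/C(=N/CCNC2CCN(c3ccccc3[N+](=O)[O-])CC2)NC#N)c1` — 4 nM
compound 2 `COC(=O)C1=C(C)N=C(C)/C(=C(/O)OC)C1c1cccc(N/C(=N/CCNC2CCN(c3ccccc3C(F)(F)F)CC2)NC#N)c1` — 14 nM
compound 3 `COC(=O)C1=C(C)N=C(C)/C(=C(/O)OC)C1c1cccc(NC(=O)NCCNC2CCN(c3ccccc3C(F)(F)F)CC2)c1` — 31 nM

In an assay on SK-N-MC cells for inhibition of Neuropeptide Y receptor type 1 (Homo sapiens) (a higher number here means a weaker inhibitor, a lower number a stronger inhibitor), compound 3 stands highest of the three numbers; the nearest is compound 2, the furthest compound 1, both gaps beyond the scatter. The next compound, compound 4 `COC(=O)C1=C(C)N=C(C)/C(=C(/O)OC)C1c1cccc(NC(=O)NCCNC2CCN(c3ccccc3O)CC2)c1`, differs from compound 3 in one place: hydroxy in place of trifluoromethyl on an aromatic carbon.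

Among the compounds with values here, only one measured step concerns the same aromatic carbon: a 3.5-fold higher number from compound 1 to compound 2 (0.54 log units; beyond the scatter). Within the data shown here, that step exchanges nitro for trifluoromethyl, so it shows the position tolerates a change of substituent with a modest shift in the number, but neither of those groups is a hydroxy, and no measured compound carries a hydroxy anywhere. Compound 2 and compound 3 share the trifluoromethyl and differ elsewhere, which says nothing about this position. Among the measured compounds shown here, the direction of the step to compound 4 is thus not fixed by the data; a change of the same order as the one measured step, or none beyond the scatter, is the working assumption, with a wide range to either side.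

Compound 4 is therefore estimated at 50 nM, within 15 nM to 200 nM. The expected step is a 1.6-fold higher number from compound 3 to compound 4 (0.21 log units; within the scatter).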

Compound 4, half-maximal inhibitory concentration: 6 nM
For compound 4 the middle estimate is 8.3-fold (0.92 log units) above the measured one, outside the stated range (below it).
By their numbers in this assay, from the lowest: compounds 1 and 4 (each within the scatter of the next); then compound 2; then compound 3.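

In this assay, a 5.2-fold lower number from compound 3 to compound 4 (0.71 log units; beyond the scatter) shows that this aromatic carbon, ortho to a large group, accepts a hydroxy in place of trifluoromethyl, and that the number falls beyond the scatter when one heavy atom carrying a hydrogen-bond donor and acceptor replaces four heavy atoms carrying neither. The earlier step, a 3.5-fold higher number from compound 1 to compound 2 (0.54 log units; beyond the scatter), showed only a rise on going to trifluoromethyl from nitro, so trifluoromethyl is now the higher-number member of both steps at this carbon, although the two steps stand on different linkers and the compounds shown offer no direct pair of nitro and hydroxy. No measured evidence accounts for the size or direction of this step.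

From the compounds shown here alone, whether a methoxy, an amine or a carboxylic acid at this carbon would hold the number near that of the hydroxy remains open, and this would help separate the role of the hydroxy hydrogen from that of the oxygen. Also open, going by these compounds, is whether hydroxy in place of trifluoromethyl gives a step of similar size on the linker of compound 2.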